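A few compounds are considered here, and "the series" means these few. Any claim that something is new, unique, unknown or untested is made for them only; others in the source may bear on it.

Compound 2 `CCNCCCOc1ccc2cc(NC(=O)c3ccc(O)c(CC=C(C)C)c3)c(=O)oc2c1C` is the starting point of this comparison. In a functional assay on SK-BR-3 cells (Homo sapiens) for antiproliferative activity (a higher number here means a weaker inhibitor, a lower number a stronger inhibitor), compound 2 gives 720 nM, the lowest of the two plain numbers available, with compound 1 within the scatter of it. Compound 1 `CC(C)=CCc1cc(C(=O)Nc2cc3ccc(OCC4CCN(C)C4)c(C)c3oc2=O)ccc1O` carries a 1-methylpyrrolidin-3-yl group on the chain carbon bound to the ring oxygen, and in this assay compound 1 gives 920 nM; the step of a 1.3-fold lower number from compound 1 to compound 2 (0.11 log units; within the scatter) is within the scatter. Compound 3 `CCCN(CCC)CCCOc1ccc2cc(NC(=O)c3ccc(O)c(CC=C(C)C)c3)c(=O)oc2c1C` carries a dipropylamino group three bonds along the chain from the ring oxygen. For compound 3 the assay reports only a limit, > 50000 nM, so the step of an at least 69-fold higher number from compound 2 to compound 3 (1.84 log units; beyond the scatter) is large.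

Compound 4 `CC(C)=CCc1cc(C(=O)Nc2cc3ccc(OCCCNCC(=O)O)c(C)c3oc2=O)ccc1O` differs from compound 2 in one place: carboxy in place of methyl on a saturated chain carbon bound to an amine nitrogen. Within the data shown here, no measured compound carries a carboxy group. The two steps at the amine end point in different directions, one flat and one steep, so the change in compound 4 is expected to cost some activity, with a wide range: a 4.2-fold higher number from compound 2 to compound 4 (0.62 log units; beyond the scatter). For compound 4 the estimate is 3000 nM, between 700 nM and 20000 nM.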

Compound 4, half-maximal inhibitory concentration: 7570 nM
Compound 4: the middle estimate sits 2.5-fold (0.40 log units) below what was measured; the range from low to high includes it.
By their numbers in this assay, from the lowest: compounds 2 and 1 (each within the scatter of the next); then compound 4. At a limit, above all of these: compound 3.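

Placing a carboxy group at the end of the chain has a clear cost at this position: the result is an 11-fold higher number from compound 2 to compound 4 (1.02 log units; beyond the scatter), and against the pyrrolidine-bearing compound it is an 8.2-fold higher number from compound 1 to compound 4 (0.92 log units; beyond the scatter). The earlier changes at the amine end were either flat or steep, whereas this one lands in between, as seen in an at least 6.6-fold lower number from compound 3 to compound 4 (0.81 log units; beyond the scatter). Compound 3 is reported only as a limit, so that last step gives a minimum and not a true size: the limit of > 50000 nM in this assay, at which 1 of the 4 values shown sits.

The compounds shown do not separate the effect of the free carboxylic acid from that of simply extending the group on the amine. A methyl ester or a primary amide in its place, or a longer chain ending in a carboxylic acid, would bear on that question.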